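Nitro to Hydrogen on a Styryl Chromone

The source may report more compounds than this note shows. Statements on the series, on what has been measured and on what is new or still open speak of the compounds shown alone.

Compound 1 `COc1cc(OC)c2c(=O)cc(/C=C/c3ccc([N+](=O)[O-])cc3)oc2c1` and compound 2 `COc1cc(OC)c2c(=O)cc(/C=C/c3ccncc3)oc2c1` share one core. In a functional assay on HeLa cells (Homo sapiens) for antiproliferative activity, read by MTT assay, with a stated time of 12 h (on this read-out higher numbers stand for weaker inhibition and lower numbers for stronger inhibition), compound 1 gives 9600 nM, the lower of the two numbers, and compound 2 gives 18800 nM; the two lie within the scatter of each other. Compound 3 `COc1cc(OC)c2c(=O)cc(/C=C/c3ccccc3)oc2c1` differs from compound 1 by hydrogen in place of nitro on an aromatic carbon. Going by the values given here, no measured pair shows this change, so the step is expected to be modest and slightly toward weaker inhibition, likely within the scatter. Compound 3 is expected to give 15000 nM in this assay, between 5000 nM and 45000 nM, a step of a 1.6-fold higher number from compound 1 to compound 3 (0.19 log units; within the scatter).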

Compound 3, half-maximal inhibitory concentration: 10100 nM
Compound 3: the middle estimate sits 1.5-fold (0.17 log units) above what was measured; low and high end bracket the measured number.
By their numbers in this assay, from the lowest: compounds 1, 3 and 2 (each within the scatter of the next).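

In this assay, hydrogen in place of nitro on this aromatic carbon gives a 1.1-fold higher number from compound 1 to compound 3 (0.02 log units; within the scatter), so the nitro group is not needed to keep the number at this level. Phenyl in place of pyridin-4-yl gives a 1.9-fold lower number from compound 2 to compound 3 (0.27 log units; within the scatter), so neither change moves the read-out beyond the scatter. Nothing available explains these results.

Going by these compounds, whether an amine or a carboxylic acid on the same aromatic carbon would give a number beyond the scatter remains open. Also open, on these data alone, is whether any change at this position can give a clear shift at all.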